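Ester for Nitrile: Expected Cytotoxicity of Compound 3

This account rests on a few compounds, and the source may have more. Where it says the series, first, only, none or still open, it means among the compounds named here.

Measured compounds:
compound 1 `O=c1[nH]c(Nc2cccc(F)c2)nc2cc(Cl)ccc12`, > 25000 nM
compound 2 `N#Cc1cccc(Nc2nc3cc(Cl)ccc3c(=O)[nH]2)c1`, > 25000 nM

In an ADME assay on Vero cells (Chlorocebus sabaeus) for cytotoxicity, read by WST assay (on this read-out higher numbers stand for lower toxicity in this test and lower numbers for higher toxicity in this test), compound 1 reaches only a limit of the assay, > 25000 nM. In this assay compound 2 likewise reaches only a limit, > 25000 nM. The step that the two limits leave unreadable from compound 1 to compound 2 therefore cannot be read, since (the limit of > 25000 nM in this assay, at which 2 of the 2 values shown sit). Compound 2 thus stands at the limit, with no number of its own in this assay.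

Compound 3 `COC(=O)c1cccc(Nc2nc3cc(Cl)ccc3c(=O)[nH]2)c1` differs from compound 2 in one place: methoxycarbonyl in place of cyano on an aromatic carbon. Going by the values given here, only one measured step bears on this exchange of one substituent on that aromatic carbon for another, and it is unreadable; the sole evidence is that both measured compounds sit at the same limit, (the limit of > 25000 nM in this assay, at which 2 of the 2 values shown sit). The expected step that the limit leaves unreadable from compound 2 to compound 3 in this assay is therefore none beyond the usual scatter, with compound 3 most likely again reported only as a limit. For compound 3 the estimate in this assay is 30000 nM, within a range from 12000 nM to 70000 nM.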

Compound 3, half-maximal cytotoxic concentration: > 25000 nM
Compound 3 gave a limit, no number (the forecaster's own chance of this, stated with the estimate: 80%); the middle value does not contradict the limit.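

Compound 3 also reaches only a limit in this assay, so no step among compound 1, compound 2 and compound 3 can be read: the limit of > 25000 nM in this assay, at which 3 of the 3 values shown sit.

The compounds shown leave open how far each true value lies past that limit, and whether fluoro, cyano and methoxycarbonyl differ at all in this assay.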